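A few compounds are considered here, and "the series" means these few. Any claim that something is new, unique, unknown or untested is made for them only; others in the source may bear on it.

Measured so far:
- compound 1, `COc1cc(-c2nn(-c3cccc(NC(=O)c4ccc(Cl)c(C(F)(F)F)c4)c3)cc2-c2ccncc2)ccc1Cl` — in a functional assay on NCI-H460 cells (Homo sapiens) for inhibition, read by sulforhodamine B assay, with a stated time of 48 h (a higher number here means a weaker inhibitor of growth, a lower number a stronger inhibitor of growth), compound 1 gives 3470 nM
- compound 2, `O=C(Nc1cccc(-n2cc(-c3ccncc3)c(-c3ccc(Cl)c(O)c3)n2)c1)Nc1cc(C(F)(F)F)cc(C(F)(F)F)c1` — in this assay compound 2 gives 413 nM

Compound 1 stands at the highest of the two numbers; compound 2, an amide-to-urea variant, sits well apart from it, beyond the scatter. For the measured compounds named here, no pair of measured compounds differing in a single place is available, so no step can be read from the data.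

The unmeasured compound 3, `COc1cc(-c2nn(-c3cccc(NC(=O)c4ccccc4)c3)cc2-c2ccncc2)ccc1Cl`, is compound 1 with one change: phenyl in place of 4-chloro-3-(trifluoromethyl)phenyl on a carbonyl carbon

Nothing in the measured set covers this change. With compound 1 already at the weak end, the expectation for compound 3 is a modest move toward a higher number in this assay, possibly within the scatter, and the step is estimated as a 2.3-fold higher number from compound 1 to compound 3 (0.36 log units; beyond the scatter). Compound 3 is therefore expected at about 8000 nM, within the range 2500 nM to 25000 nM.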

Compound 3, concentration for 50% growth inhibition: 394 nM
Beside the measured number, compound 3's estimate is 20-fold (1.31 log units) above it; measured number below the stated range.
By their numbers in this assay, from the lowest: compounds 3 and 2 (each within the scatter of the next); then compound 1.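

In this assay, for the compounds shown here, phenyl in place of 4-chloro-3-(trifluoromethyl)phenyl on the carbonyl carbon gives an 8.8-fold lower number from compound 1 to compound 3 (0.94 log units; beyond the scatter) and is the first step that can be read at this position. On the core of compound 1, therefore, the chlorine and trifluoromethyl groups are not needed for growth inhibition, and the unsubstituted phenyl gives the lower number despite being the smaller group. No supporting data bear on why the number moves.

The step removes the chlorine and the trifluoromethyl together, so the contribution of each cannot be separated. Also open, as far as these compounds go, is how the number would respond to an amine or a carboxylic acid on this phenyl, or to a longer chain in its place on the carbonyl carbon.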